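The compounds below may be only part of what the source reports. "The series", "measured", "known", "first", "only" and "open" are said of these compounds alone.

Series notes. Compound 1 `CN(C)c1ccc(C(=O)Nc2cccc(NC(=O)COc3ccc4c(c3)NC(=O)CC4)c2)cc1` gives 3140 nM in an assay on isolated protein for inhibition of Rho-associated protein kinase 2 (Homo sapiens), read by scintillation counting, radiometric assay and 33P incorporation, with a stated time of 40 min, in the presence of a further agent that is not named here (a lower number here means a stronger inhibitor, a higher number a weaker inhibitor), and compound 2 `Cc1c(OCC(=O)Nc2cccc(NC(=O)c3ccc(N(C)C)cc3)c2)ccc2c(=O)ccoc12` gives 4160 nM in the same assay. Compound 3 `O=C(COc1ccc2c(=O)ccoc2c1)Nc1cccc(NC(=O)c2ccc(F)cc2)c1` gives 54 nM in this assay, the lowest of the three numbers, with the gaps to compound 1 and to compound 2 both well beyond the scatter, so compound 3 is the strongest inhibitor measured so far. Within the data shown here, compound 1 and compound 2 carry a different amide end and different cores, so no single-change step to compound 3 can be read from them.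

Compound 4 `O=C(COc1ccc2c(=O)ccoc2c1)Nc1cccc(NC(=O)c2cccc([N+](=O)[O-])c2)c1` is not yet measured. It differs from compound 3 by 3-nitrophenyl in place of 4-fluorophenyl on a carbonyl carbon. Among the measured compounds shown here, no measured pair shows a change of this kind, so the size of the step is uncertain; a modest loss, near the edge of the scatter, is expected as a 2.2-fold higher number from compound 3 to compound 4 (0.35 log units; beyond the scatter). For compound 4 the estimated value in this assay is 120 nM, within a range of 30 nM to 500 nM.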

Compound 4, half-maximal inhibitory concentration: 41 nM
For compound 4 the middle estimate is 2.9-fold (0.47 log units) above the measured one, within the range that was stated.
By their numbers in this assay, from the lowest: compounds 4 and 3 (each within the scatter of the next); then compounds 1 and 2 (each within the scatter of the next).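

In this assay, among these compounds, 3-nitrophenyl in place of 4-fluorophenyl on a carbonyl carbon gives a 1.3-fold lower number from compound 3 to compound 4 (0.12 log units; within the scatter), the first single-change step. At this place, then, the two aromatic groups are not told apart, although the entering group is larger and carries a nitro group. No supporting data bear on this result.

The compounds shown do not separate the identity of the ring substituent from its place on the ring. Going by these compounds, how plain phenyl, 3-aminophenyl or 3-carboxyphenyl would read at this place remains open.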